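A few compounds are considered here, and "the series" means these few. Any claim that something is new, unique, unknown or untested is made for them only; others in the source may bear on it.

Compound 1, `CCc1cc(C(C)=O)c(O)cc1OCCCCC#N`, gives 57% in an assay on isolated protein for binding affinity to leukotriene B4 receptor 1 (Homo sapiens), tested at 1 uM; on this read-out higher numbers stand for more inhibition at the one concentration tested (going by the name of the read-out) and lower numbers for less inhibition.
Compound 2, `C=CCc1cc(C(C)=O)c(O)cc1OCCCCC#N`, gives 57% in this assay.
Compound 3, `C=CCc1cc(C(C)=O)c(O)cc1OCc1ccc(C#N)cc1`, gives 28% in this assay.

Compound 3 stands lowest of the three, with compound 1 and compound 2 both beyond the scatter above it. How the core of compound 3 differs from that of compound 2 is not broken down here. Compound 4, `CCc1cc(C(C)=O)c(O)cc1OCc1ccc(C#N)cc1`, has not yet been measured in this assay. It differs from compound 3 by methyl in place of vinyl on a saturated chain carbon bound to an aromatic carbon. The same change occurs once more among these compounds, from compound 2 to compound 1, as methyl in place of vinyl on a saturated chain carbon bound to an aromatic carbon; at the same place on the chain, that step made no change at the digits printed from compound 2 to compound 1 (within the scatter). That earlier step, no change at the digits printed from compound 2 to compound 1 (within the scatter), is the basis for what is expected. Compound 4 is therefore expected to move by no change at the digits printed from compound 3 to compound 4 (within the scatter). The estimate for compound 4 is 28%.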

Compound 4, a percentage reported as inhibition, at one concentration (the size of the read-out at that concentration, not a potency): 11%
Estimate against measurement, compound 4: 17 percentage points above; measured number below the stated range.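

In this assay, the change of allyl to ethyl gave a number 17 percentage points lower from compound 3 to compound 4 (beyond the scatter). The same change therefore did not carry over with the same size from one core to the other: the same change on two cores in this assay, no change at the digits printed (within the scatter) from compound 2 to compound 1 and a number 17 percentage points lower (beyond the scatter) from compound 3 to compound 4, 17 percentage points apart, beyond the scatter of two such steps This shows that, across these two pairs, the result of the change was not independent of the core, but it does not show which feature of the cores accounts for the gap, and two pairs give no rule for any further core.

The compounds shown leave open how the change would behave on a core carrying a carboxylic acid in place of the nitrile. They also leave open what a longer chain, such as propyl, in place of ethyl would give on either core.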